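Permeability notes: amide substituent change, compound 2 to 3

The source may report more compounds than this note shows. Statements on the series, on what has been measured and on what is new or still open speak of the compounds shown alone.

Measured so far:
compound 1 `Cc1cnc(NC(=O)c2cc(Oc3ccc(C(=O)N(C)C)cc3)c3cc(C)oc3c2)cn1` — 5.9 10^-6 cm/s
compound 2 `Cc1cc2c(Oc3cnc(C(=O)N4CC(C)C4)cn3)cc(C(=O)Nc3cnccn3)cc2o1` — 14.9 10^-6 cm/s

In an ADME assay on MDCKII-LE cells (Canis lupus familiaris) for permeability (a lower number here means that the compound crosses the layer more slowly, a higher number that the compound crosses the layer faster), compound 2 holds the higher of the two numbers; compound 1 reads lower, and the two values are separated by more than the usual scatter. Compound 3 `Cc1cc2c(Oc3cnc(C(=O)N(C)C)cn3)cc(C(=O)Nc3cnccn3)cc2o1` is not yet measured. It differs from compound 2 in one place: dimethylamino in place of 3-methylazetidin-1-yl on a carbonyl carbon. Nothing measured yet connects this kind of change to a shift in this assay. The expected step of a 1.4-fold lower number from compound 2 to compound 3 (0.13 log units; within the scatter) is small, likely within the scatter, leaning downward. Compound 3 is expected near 11 10^-6 cm/s, in the range 5.5 10^-6 cm/s to 22 10^-6 cm/s.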

Compound 3, apparent permeability: 30 10^-6 cm/s
Beside the measured number, compound 3's estimate is 2.7-fold (0.44 log units) below it, and the stated range ends below it.
By their numbers in this assay, from the lowest: compound 1; then compounds 2 and 3 (each within the scatter of the next).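

In this assay, going by these compounds alone, dimethylamino in place of 3-methylazetidin-1-yl on a carbonyl carbon gives a 2.0-fold higher number from compound 2 to compound 3 (0.30 log units; within the scatter), the first reading of any change at this place. The four-membered ring can go without a shift beyond the scatter, so this carbonyl carbon carries the open dimethylamino as well as the ring. Nothing measured bears on the reason for this step.

As far as these compounds go, only these two groups are compared here, so a morpholine or diethylamino group on this carbonyl carbon remains open. Whether an amide bearing a carboxylic acid would stay within the scatter of these compounds also remains open.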